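Methoxyphenyl in place of benzisoxazole on the piperazine

This account rests on a few compounds, and the source may have more. Where it says the series, first, only, none or still open, it means among the compounds named here.

Compound 2 `O=C(CCCCCN1CCN(c2noc3ccccc23)CC1)NC1CCCc2ccccc21` and compound 1 `COc1ccc2c(c1)C(NC(=O)CCCN1CCN(c3ccccc3OC)CC1)CCC2` have been measured in an assay on HEK293 cells for displacement of a labelled ligand from 5-hydroxytryptamine receptor 7 (Rattus norvegicus); a higher number here means a weaker inhibitor, a lower number a stronger inhibitor. Compound 2 gives 125 nM, and compound 1 gives 129 nM; the two values lie within the scatter of each other. Compound 3 `COc1cccc(N2CCN(CCCCCC(=O)NC3CCCc4ccccc43)CC2)c1` is not yet measured. It differs from compound 2 by a group of 8 heavy atoms (7 carbon, 1 oxygen; one six-membered aromatic ring of carbon only) in place of a group of 9 heavy atoms (7 carbon, 1 nitrogen, 1 oxygen; one five-membered aromatic ring with 2 hetero atoms, one six-membered aromatic ring of carbon only), on an amine nitrogen in a ring. Going by the values given here, no step between measured compounds bears on this change, so the expected step of a 1.3-fold higher number from compound 2 to compound 3 (0.11 log units; within the scatter) is none beyond the scatter, partly because compound 1, which also carries a methoxyphenyl on that nitrogen, gives 129 nM. For compound 3 the estimate in this assay is 160 nM, expected between 45 nM and 600 nM.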

Compound 3, inhibition constant: 119 nM
Compound 3: the middle estimate sits 1.3-fold (0.13 log units) above what was measured, and the stated range covers the measured number.
By their numbers in this assay, from the lowest: compounds 3, 2 and 1 (each within the scatter of the next).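

Putting 3-methoxyphenyl on the amine nitrogen in the ring, in place of the group with a five-membered aromatic ring, gives a 1.1-fold lower number from compound 2 to compound 3 (0.02 log units; within the scatter) in this assay. Going by these compounds alone, with the rest of compound 2 unchanged, this is the first direct comparison at this position, and the step stays within the scatter. No measurement available explains this result.

Compound 1 differs from compound 3 in more than one place, so the effect of moving the methoxy group remains unresolved. Also open, going by these compounds, is whether a plain phenyl or a pyridine ring on that nitrogen would stay within the scatter of compound 2.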